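This account rests on a few compounds, and the source may have more. Where it says the series, first, only, none or still open, it means among the compounds named here.

Compound 1 `CC(C)=CC(=O)NC(=N)N`, compound 3 `CC(C)=CCC/C(C)=C/C(=O)NC(=N)N` and compound 2 `CC(C)=CCC/C(C)=C/CC/C(C)=C/C(=O)NC(=N)NC(=O)/C=C(\C)CC/C=C(\C)CCC=C(C)C` were examined in a functional assay on A549 cells (Homo sapiens) for inhibition, read by MTT assay, with a stated time of 72 h; a higher number here means a weaker inhibitor of growth, a lower number a stronger inhibitor of growth. In this assay compound 1 reaches only a limit, > 100000 nM, and no number. Compound 3 gives 76500 nM, and compound 2 gives 18500 nM, the lowest of the two numbers recorded. The change hydrogen in place of 3-methylbut-2-en-1-yl on a saturated chain carbon bound to a double-bonded chain carbon produced an at least 1.3-fold higher number from compound 3 to compound 1 (0.11 log units; that floor lies within the scatter), with the value of compound 1 being (the limit of > 100000 nM in this assay, at which 1 of the 3 values shown sits). The difference between the cores of compound 2 and compound 3 is not broken down here. Compound 4 `CC(C)=CCC/C(C)=C/CC/C(C)=C/C(=O)NC(=N)NC(=O)/C=C(\C)CCC=C(C)C` has not yet been measured; it arises from compound 2 by hydrogen in place of 3-methylbut-2-en-1-yl on a saturated chain carbon bound to a double-bonded chain carbon, the same change as from compound 3 to compound 1. Since compound 1 gave an at least 1.3-fold higher number from compound 3 to compound 1 (0.11 log units; that floor lies within the scatter), compound 4 is expected to show a modestly higher number than compound 2, about a 1.9-fold higher number from compound 2 to compound 4 (0.28 log units; within the scatter). The estimate for compound 4 in this assay is 35000 nM, expected to lie between 15000 nM and 90000 nM.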

Compound 4, concentration for 50% growth inhibition: 38900 nM
Beside the measured number, compound 4's estimate is 1.1-fold (0.05 log units) below it; the range from low to high includes it.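

In this assay, hydrogen in place of 3-methylbut-2-en-1-yl on a saturated chain carbon bound to a double-bonded chain carbon gives a 2.1-fold higher number from compound 2 to compound 4 (0.32 log units; beyond the scatter), so on this core the change makes compound 4 a modestly weaker inhibitor of growth. Among these compounds, the change has now been read on only two cores, and this does not show that it has the same size on both: the same change on two cores in this assay, an at least 1.3-fold higher number (0.11 log units; that floor lies within the scatter) from compound 3 to compound 1 and a 2.1-fold higher number (0.32 log units; beyond the scatter) from compound 2 to compound 4; the limit leaves it open whether they differ. Compound 1 reaches only a limit, > 100000 nM, and that is not a number.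

The compounds shown leave open how the number in this assay would move with a saturated chain, such as a pentyl chain, in place of 3-methylbut-2-en-1-yl, or with a longer chain at that place. They also leave open whether an amine or a carboxylic acid at the end of the chain would be tolerated on either core.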